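The source may hold more compounds than are shown below. What is called first, only, known or untested is meant among the compounds shown, and "the series" means these compounds.

Three compounds share one core and differ only in the aryl group that sits on the double-bonded chain carbon attached to the ring. Compound 1 `COc1ccc(/C=C2/SC(N3CCC[C@H]3C(=O)Nc3ccc4ncnc(Nc5cccc(Cl)c5)c4c3)=NC2=O)cc1` carries a 4-methoxyphenyl there, and in a functional assay on HepG2 cells (Homo sapiens) for antiproliferative activity, read by MTT assay (a higher number here means a weaker inhibitor, a lower number a stronger inhibitor), compound 1 gives 19000 nM. Compound 2 `O=C1N=C(N2CCC[C@H]2C(=O)Nc2ccc3ncnc(Nc4cccc(Cl)c4)c3c2)S/C1=C/c1cccc(Cl)c1` carries a 3-chlorophenyl in its place, and compound 2 gives 27600 nM. Compound 3 `O=C1N=C(N2CCC[C@H]2C(=O)Nc2ccc3ncnc(Nc4cccc(Cl)c4)c3c2)S/C1=C/c1ccccc1Cl` carries a 2-chlorophenyl, and compound 3 gives 28100 nM. On its face the number of compound 3 is the largest of the three, yet the step of a 1.5-fold higher number from compound 1 to compound 3 (0.17 log units; within the scatter) and the step of a 1.0-fold higher number from compound 2 to compound 3 (0.01 log units; within the scatter) both sit within the scatter, so the three cannot be told apart. Compound 4 `O=C1N=C(N2CCC[C@H]2C(=O)Nc2ccc3ncnc(Nc4cccc(Cl)c4)c3c2)S/C1=C/c1ccccc1F` takes the next step: fluoro in place of chloro on an aromatic carbon. Among the measured compounds shown here, no measured pair swaps chloro for fluoro, so the only guide is that changing the aryl group on this chain, as in a 1.5-fold higher number from compound 1 to compound 2 (0.16 log units; within the scatter), moved the number little. For compound 4 the expected step is therefore a 1.0-fold lower number from compound 3 to compound 4 (0.00 log units; within the scatter), nothing beyond the scatter. Compound 4 is estimated at 28000 nM, with a range from 12000 nM to 65000 nM.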

Compound 4, half-maximal inhibitory concentration: 18200 nM
Estimate against measurement, compound 4: 1.5-fold (0.19 log units) above; low and high end bracket the measured number.
By their numbers in this assay, from the lowest: compounds 4, 1, 2 and 3 (each within the scatter of the next).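

In this assay, among the compounds shown here, the swap of chloro for fluoro on the aromatic carbon gives a 1.5-fold lower number from compound 3 to compound 4 (0.19 log units; within the scatter) and so adds a first exchange of one halogen for another at this place, one that does not separate the two compounds. The comparisons with the other two aryl groups give a 1.5-fold lower number from compound 2 to compound 4 (0.18 log units; within the scatter) and a 1.0-fold lower number from compound 1 to compound 4 (0.02 log units; within the scatter) as well, so all four aryl groups on this chain carbon stay within the scatter of one another. Nothing measured here offers an explanation for this flat result.

The aryl groups shown carry only chloro, fluoro or methoxy, so whether an amine, a carboxylic acid or a longer chain on this ring would move the number beyond the scatter stays open. Also open, on these data alone, is whether fluoro in place of chloro on the 3-chlorophenyl group would behave the same way.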